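This account rests on a few compounds, and the source may have more. Where it says the series, first, only, none or still open, it means among the compounds named here.

Of the compounds shown here, two of a shared core have been measured so far. Compound 1 `CC1(C)C(=O)N(c2ccc(Cl)cc2Cl)c2ncccc21` gives 8% in a functional assay on the whole organism (Pleural cavity) for inhibition, with Rattus norvegicus as the target, at a dose of 25 mg/kg (on this read-out lower numbers stand for less inhibition and higher numbers for more inhibition at the one dose given (going by the name of the read-out)), and compound 2 `CSC1(C)C(=O)N(c2ccccc2)c2ncccc21` gives 53% in this assay, the higher of the two numbers and beyond the scatter apart from compound 1. Compound 3 `COCCSC1(C)C(=O)N(c2ccccc2)c2ncccc21` differs from compound 2 by methoxymethyl in place of hydrogen on a saturated chain carbon bound to a sulfur. For the measured compounds named here, no measured pair shows this kind of change, so its effect is uncertain; a step from compound 2 to compound 3 of a number 8 percentage points lower from compound 2 to compound 3 (within the scatter) is expected, within the scatter or slightly downward. Compound 3 is therefore expected to give about 45% in this assay, between 20% and 68%.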

Compound 3, a percentage reported as inhibition, in the whole organism at one dose (the size of the read-out at that dose, not a potency): 23%
The estimate for compound 3 lay 22 percentage points above the measured number; measured number inside the range.
By their numbers in this assay, from the lowest: compound 1; then compound 3; then compound 2.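

On the saturated chain carbon bound to a sulfur, methoxymethyl in place of hydrogen gives a number 30 percentage points lower from compound 2 to compound 3 (beyond the scatter) in this assay. This shows that the read-out responds to a change at this position, which compound 1 and compound 2 could not show, since they differ in more than one place. Nothing measured here bears on why the number falls.

On these data alone, it remains open whether the drop follows the added chain length or the ether oxygen, which an unbranched propylsulfanyl chain would separate. As far as these compounds go, how an amine or a carboxylic acid at the end of the chain would compare also remains open.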